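Compound 1 to compound 3: a step without anchor

The compounds below may be only part of what the source reports. "The series", "measured", "known", "first", "only" and "open" are said of these compounds alone.

In a functional assay on HepG2 cells (Homo sapiens) for cytotoxicity, read by sulforhodamine B assay, with a stated time of 48 h (a lower number here means a stronger inhibitor, a higher number a weaker inhibitor), compound 1 `COc1ccc(/C=C/C(=O)c2ccc(N)c(-c3ccc(F)cc3)c2)cc1O` stands at "not determined" (no result reported) and so gives no number from which to measure a step. For the measured compounds named here, the only number nearby is that of compound 2 `COc1ccc(/C=C/C(=O)c2cccc(-c3cccc(F)c3)c2)cc1` at 1720 nM in this assay, and this compound also differs from compound 1 in more than one place.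

Compound 3 `Nc1ccc(C(=O)/C=C/c2ccc(O)c(F)c2)cc1-c1ccc(F)cc1` carries 3-fluoro-4-hydroxyphenyl in place of 3-hydroxy-4-methoxyphenyl on a double-bonded chain carbon bound to a double-bonded chain carbon. Going by the values given here, with no measured step for this exchange, no direction can be assigned, and the expectation in this assay is for no step beyond the scatter. The estimate therefore leans loosely on compound 2 at 1720 nM and stays wide. For compound 3 the expected value is 2500 nM with an estimated range from 500 nM to 12000 nM in this assay.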

Compound 3, half-maximal inhibitory concentration: 11700 nM
Compound 3: middle estimate off by 4.7-fold (0.67 log units), on the low side, within the range that was stated.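

No new step can be read between compound 1 and compound 3: compound 1 has no single number in this assay. The compounds shown leave open what exchanging 3-hydroxy-4-methoxyphenyl for 3-fluoro-4-hydroxyphenyl does on its own. No evidence bears on this result.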